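Aryl swap on the saturated ring carbon of compound 1

This account rests on a few compounds, and the source may have more. Where it says the series, first, only, none or still open, it means among the compounds named here.

Within the data shown here, compound 1 `CCCCCCCCCCCCCCCCCCNC(=O)[C@H]1CSC(c2c[nH]c3ccccc23)N1` gives 1300 nM in a functional assay on PPC-1 cells (Homo sapiens) for antiproliferative activity, read by sulforhodamine B assay (on this read-out higher numbers stand for weaker inhibition and lower numbers for stronger inhibition), the lowest of the three numbers measured so far. Compound 2 `CCCCCCCCCCCCCCCCCCNC(=O)[C@H]1CSC(c2ccc(Br)cc2)N1` gives 3700 nM and compound 3 `CCCCCCCCCCCCCCCCCCNC(=O)[C@H]1CSC(c2c(Cl)cccc2Cl)N1` gives 17100 nM; both steps from compound 1 run upward, a 2.8-fold higher number from compound 1 to compound 2 (0.45 log units; beyond the scatter) and a 13-fold higher number from compound 1 to compound 3 (1.12 log units; beyond the scatter), with a 4.6-fold higher number from compound 2 to compound 3 (0.66 log units; beyond the scatter) between the two phenyl analogues. Compound 4 `CCCCCCCCCCCCCCCCCCNC(=O)[C@H]1CSC(c2ccc(F)c(Br)c2)N1` carries 3-bromo-4-fluorophenyl in place of 1H-indol-3-yl on a saturated ring carbon. The step to compound 2, a bromine-bearing phenyl like that of compound 4, bears most closely; the step to compound 3 is the larger of the two. For compound 4 a modest upward move is expected, a 3.1-fold higher number from compound 1 to compound 4 (0.49 log units; beyond the scatter). The estimate for compound 4 is 4000 nM, within 1500 nM to 11000 nM.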

Compound 4, half-maximal inhibitory concentration: 4700 nM
Compound 4: middle estimate off by 1.2-fold (0.07 log units), on the low side; measured number inside the range.
By their numbers in this assay, from the lowest: compound 1; then compounds 2 and 4 (each within the scatter of the next); then compound 3.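

Compound 4 does not separate from the other bromine-bearing phenyl, a 1.3-fold higher number from compound 2 to compound 4 (0.10 log units; within the scatter), so the 3-bromo-4-fluorophenyl and 4-bromophenyl groups cannot be told apart at this position. A second bromine-bearing phenyl also falls short of the 1H-indol-3-yl group, a 3.6-fold higher number from compound 1 to compound 4 (0.56 log units; beyond the scatter), while the 2,6-dichlorophenyl group stays apart from this one too, a 3.6-fold lower number from compound 3 to compound 4 (0.56 log units; beyond the scatter). No data at hand explain these steps.

Open, from the compounds shown here alone, is whether a 1-methylindol-3-yl group, or a phenyl carrying a hydroxyl or an amine, would match compound 1.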